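The source may report more compounds than this note shows. Statements on the series, on what has been measured and on what is new or still open speak of the compounds shown alone.

Compound 1 `Cc1ccc(S(=O)(=O)NC(=O)Nc2ccccc2C(=O)/C=C/c2ccc(O)cc2)cc1`: in an ADME assay on the whole organism for cytotoxicity, with Artemia salina as the target, with a stated time of 24 h (on this read-out lower numbers stand for an effect already at smaller amounts and higher numbers for an effect only at larger amounts of compound), compound 1 gives 24.3 ug/mL.
Compound 2 `COc1cc(/C=C/C(=O)c2ccccc2NC(=O)NS(=O)(=O)c2ccc(C)cc2)ccc1O`: in this assay compound 2 gives 17.8 ug/mL.

Among the measured compounds shown here, compound 2 carries the lowest of the two numbers, but its only neighbour, compound 1, sits within the usual scatter of it, so the two cannot be told apart on these data. Compound 3 `Cc1ccc(S(=O)(=O)NC(=O)Nc2ccccc2C(=O)/C=C/c2cc(O)ccc2[N+](=O)[O-])cc1` has not yet been measured. It differs from compound 2 in one place: 5-hydroxy-2-nitrophenyl in place of 4-hydroxy-3-methoxyphenyl on a double-bonded chain carbon bound to a double-bonded chain carbon. For the measured compounds named here, the single measured step, a 1.4-fold lower number from compound 1 to compound 2 (0.14 log units; within the scatter), altered the same ring and stayed within the scatter. The ring that enters carries a nitro group, on which nothing has been measured, so no direction can be read from the data. The expected step in this assay is therefore one of no size beyond the scatter, a 1.1-fold higher number from compound 2 to compound 3 (0.05 log units; within the scatter), with wide uncertainty. Compound 3 is estimated at 20 ug/mL, with a range from 8 ug/mL to 50 ug/mL.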

Compound 3, concentration for half-maximal effect: 18.3 ug/mL
Estimate against measurement, compound 3: 1.1-fold (0.04 log units) above, within the range that was stated.
By their numbers in this assay, from the lowest: compounds 2, 3 and 1 (each within the scatter of the next).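

In this assay the place on a double-bonded chain carbon bound to a double-bonded chain carbon now takes a much larger change than a single methoxy, and it reads as a 1.0-fold higher number from compound 2 to compound 3 (0.01 log units; within the scatter) and as a 1.3-fold lower number from compound 1 to compound 3 (0.12 log units; within the scatter) when set against the other ring. With 4-hydroxyphenyl, 4-hydroxy-3-methoxyphenyl and 5-hydroxy-2-nitrophenyl at this place, compounds 1, 2 and 3 cannot be told apart on this read-out, so a nitro group and a shifted hydroxy show no step beyond the scatter here. Nothing measured on these compounds speaks to why the number holds across these rings.

All three rings carry a hydroxy, so a ring without one remains an open case. Also open, from the compounds shown here alone, is whether an amine or a carboxylic acid on this ring, or a longer chain in its place, would give a step beyond the scatter.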